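A few compounds are considered here, and "the series" means these few. Any claim that something is new, unique, unknown or untested is made for them only; others in the source may bear on it.

The shared core carries a hydroxymethyl group flanked by a tert-butyl, an isopropyl and a pendant aryl group. Compound 1 `CC(C)c1cc(C(C)(C)C)cc(-c2ccc(F)cc2)c1CO` bears a 4-fluorophenyl, and in a functional assay on RKE cells for antagonist activity at Vasoactive intestinal polypeptide receptor 1 (Rattus norvegicus), read by HTRF and cAMP accumulation, with stated times of 10 min and 30 min (on this read-out lower numbers stand for stronger inhibition and higher numbers for weaker inhibition), compound 1 gives 740 nM. Compound 2 `Cc1ccccc1-c1cc(C(C)(C)C)cc(C(C)C)c1CO` carries a 2-methylphenyl instead; in this assay compound 2 gives > 50000 nM, which is a limit of the assay and not a number. The step of an at least 67-fold higher number from compound 1 to compound 2 (1.82 log units; beyond the scatter) is therefore at least as large as stated. Compound 3 `CC(C)c1cc(C(C)(C)C)cc(-c2cccc(C#N)c2)c1CO`, with a 3-cyanophenyl, also reaches only a limit: in this assay compound 3 gives > 50000 nM. Compound 2 thus stands at the limit of > 50000 nM in this assay, at which 2 of the 3 values shown sit, together with compound 3, while compound 1 alone returns a measured number.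

Compound 4 `COc1ccccc1-c1cc(C(C)(C)C)cc(C(C)C)c1CO` differs from compound 2 by methoxy in place of methyl on an aromatic carbon. Going by the values given here, no measured step exchanges methyl for methoxy; the only step altering the pendant group, from compound 1 to compound 2, was large and toward weaker inhibition. With compound 2 already at the limit, compound 4 is expected to remain near it, at 60000 nM, within 10000 nM to 200000 nM. The expected step that the limit leaves unreadable from compound 2 to compound 4 is thus judged to lie within the scatter, most likely returning another limit.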

Compound 4, half-maximal inhibitory concentration: 820 nM
Compound 4: middle estimate off by 73-fold (1.86 log units), on the high side; measured number below the stated range.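

Methoxy in place of methyl, on an aromatic carbon ortho to a large group, brings an at least 60-fold lower number from compound 2 to compound 4 (1.78 log units; beyond the scatter), so a substituent at this place does not by itself abolish inhibition in this assay. Going by these compounds alone, until now, the only step at the pendant group ran toward weaker inhibition, whereas compound 4 returns a measured number, 820 nM, after an exchange of a single small group. The full size of this step cannot be read, since compound 2 stands at a limit: the limit of > 50000 nM in this assay, at which 2 of the 4 values shown sit.

The compounds shown leave open whether an ethoxy, a hydroxy or an amine at this place would behave like the methoxy of compound 4. They also do not tell whether methoxy elsewhere on the pendant ring would do the same.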